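Ester variation on a shared core: cytotoxicity notes

The source may hold more compounds than are shown below. What is called first, only, known or untested is meant among the compounds shown, and "the series" means these compounds.

Measured so far:
compound 1 `CC(C)(C)c1ccc(OC(=O)c2cn(-c3ccccc3)nc2-c2cccnc2)cc1` — in a functional assay on MDA-MB-231 cells (Homo sapiens) for cytotoxicity, read by MTT assay, with a stated time of 48 h (on this read-out lower numbers stand for stronger inhibition and higher numbers for weaker inhibition), compound 1 gives > 100000 nM, a limit of the assay.
compound 2 `Cc1ccc(C(C)C)c(OC(=O)c2cn(-c3ccccc3)nc2-c2cccnc2)c1` — in this assay compound 2 gives > 100000 nM, likewise a limit.

Compound 2 therefore stands at the limit, with no number. The step that the two limits leave unreadable from compound 1 to compound 2 cannot be sized, and the limit of > 100000 nM in this assay, at which 2 of the 2 values shown sit, is all that is known. Compound 3 `O=C(Oc1ccc2ccccc2c1)c1cn(-c2ccccc2)nc1-c1cccnc1` carries naphthalen-2-yl in place of 2-isopropyl-5-methylphenyl on an oxygen next to a carbonyl group. Among the measured compounds shown here, no measured step bears on this change, so no direction can be read from the series; compound 3 is expected to stay near the limit, with a step that the limit leaves unreadable from compound 2 to compound 3 expected as no step beyond the scatter. Compound 3 is estimated at 150000 nM, within 30000 nM to 1000000 nM.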

Compound 3, half-maximal inhibitory concentration: > 100000 nM
Compound 3: only a limit was reported (the forecaster's own chance of this, stated with the estimate: 70%); the middle value does not contradict the limit.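

Compound 3 sits at a limit, as do compound 1 and compound 2, so no step among the three can be read: the limit of > 100000 nM in this assay, at which 3 of the 3 values shown sit.

The compounds shown leave open whether any ester on the shared core reaches a measurable value in this assay.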